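Aryl ether in place of aryl thioether: working notes

The compounds below may be only part of what the source reports. "The series", "measured", "known", "first", "only" and "open" are said of these compounds alone.

Compound 3 `Nc1cc(N)c2nc(-c3ccccc3)c(Sc3ccc(Cl)c(Cl)c3)nc2c1` gives 12600 nM in a functional assay on NCI-H23 cells (Homo sapiens) for inhibition, read by sulforhodamine B assay, with a stated time of 48 h (on this read-out lower numbers stand for stronger inhibition of growth and higher numbers for weaker inhibition of growth), the highest of the two numbers at hand; compound 1 `Nc1cc(N)c2nc(-c3ccccc3)c(NCc3ccc(F)cc3)nc2c1` gives 2400 nM, and the step of a 5.3-fold higher number from compound 1 to compound 3 (0.72 log units; beyond the scatter) is modest but beyond the scatter. Compound 2 `COc1ccc(Sc2nc3cc(N)cc(N)c3nc2-c2ccccc2)cc1` is reported only as a limit of the limit of < 100000 nM in this assay, at which 1 of the 3 values shown sits, so compound 2 gives < 100000 nM and neither a step that the limit leaves unreadable from compound 1 to compound 2 nor a step that the limit leaves unreadable from compound 2 to compound 3 can be read.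

Compound 4 `Nc1cc(N)c2nc(-c3ccccc3)c(Oc3ccc(F)cc3)nc2c1` differs from compound 3 by 4-fluorophenoxy in place of (3,4-dichlorophenyl)sulfanyl on an aromatic carbon. Going by the values given here, no measured step changes sulfur to oxygen within the same aryl series, so the only bearing evidence is the modest step from the benzylamine of compound 1 to the thioether of compound 3. Compound 4 is therefore expected to fall between these two, with an estimated 6000 nM (range 1500 nM to 25000 nM), a step of a 2.1-fold lower number from compound 3 to compound 4 (0.32 log units; beyond the scatter).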

Compound 4, concentration for 50% growth inhibition: 20900 nM
Beside the measured number, compound 4's estimate is 3.5-fold (0.54 log units) below it; measured number inside the range.
By their numbers in this assay, from the lowest: compound 1; then compounds 3 and 4 (each within the scatter of the next).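

In this assay, 4-fluorophenoxy in place of (3,4-dichlorophenyl)sulfanyl gives a 1.7-fold higher number from compound 3 to compound 4 (0.22 log units; within the scatter), so these two groups are not told apart at this position, even though the linking atom and the ring substituents both change. 4-fluorophenoxy in place of (4-fluorobenzyl)amino gives an 8.7-fold higher number from compound 1 to compound 4 (0.94 log units; beyond the scatter), so compound 1 now stands apart from both the thioether and the ether. Steps to or from compound 2 cannot be read: the limit of < 100000 nM in this assay, at which 1 of the 4 values shown sits.

From the compounds shown here alone, the effect of oxygen against sulfur with one aryl group held constant remains open. So does the reading of a primary amine or a carboxylic acid at this position.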